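Opening the ring of compound 3: working notes

A few compounds are considered here, and "the series" means these few. Any claim that something is new, unique, unknown or untested is made for them only; others in the source may bear on it.

In a functional assay on Bel-7402 cells (Homo sapiens) for inhibition, read by MTT assay, with a stated time of 24 h, tested at 10 ug/mL (on this read-out lower numbers stand for less inhibition of growth and higher numbers for more inhibition of growth at the one concentration tested), compound 1 (`O=C(O)CCCCC(CCSC(=O)c1ccccc1)SC(=O)c1ccccc1`) gives 2.76% and compound 2 (`O=C(CCCCC1CCSS1)Nc1cccc(C(F)(F)F)c1`) gives 4.43% in this small set. Compound 3 (`O=C(CCCCC1CCSS1)Nc1ccc(OC(F)(F)F)cc1`) stands at 1.24% here, within the scatter of both other compounds, so the three numbers carry no meaningful order.

The step to compound 4 (`O=C(CCCCC(S)CCS)Nc1ccc(OC(F)(F)F)cc1`) is a group of 5 heavy atoms (3 carbon, 2 sulfur; no ring) in place of a group of 5 heavy atoms (3 carbon, 2 sulfur; one five-membered non-aromatic ring with 2 hetero atoms), on a saturated chain carbon, four bonds along the chain from a carbonyl carbon and leaves a 1,3-disulfanylpropyl group on that chain carbon. Among the compounds with values here, no measured pair isolates this change, so the data offer no direct guide to its size. Compound 1 also has an open chain at this place and gives 2.76% in this assay despite that, although it differs in other parts too. A large gain is therefore not expected. Expected is a number 4.8 percentage points higher from compound 3 to compound 4 (within the scatter) in this assay as a small rise, with no step beyond the scatter. For compound 4 the estimate is 6% with an expected range of 0.5% to 18% at the one concentration tested.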

Compound 4, percent growth inhibition at one concentration: 14.2%
Estimate against measurement, compound 4: 8.2 percentage points below; the measured number falls inside the stated range.
By their numbers in this assay, from the lowest: compounds 3, 1, 2 and 4 (each within the scatter of the next, the first and the last beyond it).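

In this assay, within the data shown here, the opening of the ring to the 1,3-disulfanylpropyl group gives a number 13 percentage points higher from compound 3 to compound 4 (beyond the scatter) and is the first step to isolate this place, on a saturated chain carbon, four bonds along the chain from a carbonyl carbon. Among these compounds, the number at this place therefore moves when the ring gives way to the open chain while the rest of the structure stays fixed, a result that no earlier pair could show. Nothing at hand explains the step.

Going by these compounds, it remains open whether both thiol groups are needed, or whether a single thiol or a chain with two methyl thioether groups would give a similar number. On these data alone, it is also open whether the same ring opening would give a step of similar size on the amide of compound 2.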